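This account rests on a few compounds, and the source may have more. Where it says the series, first, only, none or still open, it means among the compounds named here.

Of the compounds shown here, three built on one shared core have been measured in a functional assay on Ehrlich cells (Mus musculus) for cytotoxicity, read by trypan blue exclusion, with a stated time of 2 h, tested at 10 ug/mL; on this read-out lower numbers stand for a weaker effect and higher numbers for a stronger effect at the one concentration tested. Compound 1 `N#CC1=C(N)N(c2ccc(S(N)(=O)=O)cc2)C2=C(CCCC2)C1c1ccccc1O` gives 10%. Compound 2 `N#CC1=C(N)N(c2ccc(S(N)(=O)=O)cc2)C2=C(CCCC2)C1/C=C/c1ccccc1` gives 50%. Compound 3 `N#CC1=C(N)N(c2ccc(S(N)(=O)=O)cc2)C2=C(CCCC2)C1c1ccc([N+](=O)[O-])cc1` gives 0%, the lowest of the three numbers: its gap to compound 1 lies within the scatter, while its gap to compound 2 is wide, as the step of a number 50 percentage points lower from compound 2 to compound 3 (beyond the scatter) shows.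

Compound 4 `N#CC1=C(N)N(c2ccc(S(N)(=O)=O)cc2)C2=C(CCCC2)C1c1ccccc1Cl` has not been measured. It differs from compound 3 at one place: 2-chlorophenyl in place of 4-nitrophenyl on a saturated ring carbon. Within the data shown here, two steps bear on this. Swapping one aryl group for another, a number 10 percentage points lower from compound 1 to compound 3 (within the scatter), stayed within the scatter, whereas the only large move, a number 40 percentage points higher from compound 1 to compound 2 (beyond the scatter), came from putting in the 2-phenylethenyl group, which compound 4 does not carry. An aryl-for-aryl exchange is therefore expected to leave the read-out roughly where it is, and the step of a number 10 percentage points higher from compound 3 to compound 4 (within the scatter) is estimated to fall within the scatter. In this assay compound 4 is expected to give about 10%, within a range from 0% to 30%.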

Compound 4, a percentage reported as activity, at one concentration (the size of the read-out at that concentration, not a potency): 0%
Compound 4: middle estimate off by 10 percentage points, on the high side, within the range that was stated.
By their numbers in this assay, from the lowest: compounds 3, 4 and 1 (each within the scatter of the next); then compound 2.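

In this assay the exchange of one aryl group for another on the saturated ring carbon gives no change at the digits printed from compound 3 to compound 4 (within the scatter) and so 2-chlorophenyl and 4-nitrophenyl cannot be told apart here. Chloro in place of hydroxy on an aromatic carbon gives a number 10 percentage points lower from compound 1 to compound 4 (within the scatter) and with that, all three compounds that carry a substituted phenyl group at this position lie within the scatter of each other. Only compound 2 goes against this pattern, with a number 50 percentage points lower from compound 2 to compound 4 (beyond the scatter) as a further large step, which sets the 2-phenylethenyl group apart from a third aryl group as well.

From the compounds shown here alone, whether that difference depends on the double bond of the chain stays open, and a saturated 2-phenylethyl chain or a plain phenyl group at this position would bear on that. Nothing measured here explains why these numbers fall as they do.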